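Swapping the sulfonyl linker for a carbonyl in compound 1

This account rests on a few compounds, and the source may have more. Where it says the series, first, only, none or still open, it means among the compounds named here.

Measured compounds:
compound 1, `COc1cc(N(Cc2nc3ccccc3[nH]2)S(=O)(=O)c2ccc(F)cc2)cc(OC)c1OC`: 7990 nM
compound 2, `COc1ccc(S(=O)(=O)N(Cc2nc3ccccc3[nH]2)c2cc(OC)c(OC)c(OC)c2)cc1OC`: 30400 nM

Compound 1 is the stronger of the two compounds measured in a functional assay on PC-3 cells (Homo sapiens) for inhibition, read by MTT assay, with a stated time of 48 h; a higher number here means a weaker inhibitor, a lower number a stronger inhibitor; compound 2 sits at the higher number, and the step of a 3.8-fold higher number from compound 1 to compound 2 (0.58 log units; beyond the scatter) is beyond the scatter. Compound 3, `COc1cc(N(Cc2nc3ccccc3[nH]2)C(=O)c2ccccc2)cc(OC)c1OC`, has not been measured. It differs from compound 1 in one place: benzoyl in place of (4-fluorophenyl)sulfonyl on a nitrogen on an aromatic ring. This is a change in the group that links the aromatic ring to the nitrogen, not a change of substituent on that ring.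

Going by the values given here, the one measured step, from compound 1 to compound 2, concerns only the aromatic ring on the sulfonyl sulfur and leaves the sulfonyl itself untouched, so it speaks to the size of change the series tolerates at this position but does not bear directly on exchanging the sulfonyl for a carbonyl. With nothing closer to lean on, the writer expects a modest loss rather than a gain, and wide uncertainty. Compound 3 is therefore estimated at 13000 nM, within a range of 3500 nM to 50000 nM, which means an expected step of a 1.6-fold higher number from compound 1 to compound 3 (0.21 log units; within the scatter).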

Compound 3, half-maximal inhibitory concentration: > 50000 nM
Compound 3: no number, only a limit; the forecaster's own chance of this, stated with the estimate: 15%; middle value at least 3.8-fold (0.58 log units) away from the limit.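

In this assay compound 3 gives > 50000 nM, which is a limit of the assay and not a number. The earlier step changed only the aromatic ring on the sulfonyl sulfur and left the sulfonyl in place, whereas this change replaces the link itself, and the exchange of (4-fluorophenyl)sulfonyl for benzoyl on the nitrogen gives an at least 6.2-fold higher number from compound 1 to compound 3 (0.79 log units; beyond the scatter). So, among the compounds shown, the two that keep the sulfonyl carry a number in this assay, while the true size of the step to the benzoyl compound remains unknown: the limit of > 50000 nM in this assay, at which 1 of the 3 values shown sits.

The exchange also removes the fluorine together with the sulfonyl, so the compounds shown do not separate the effect of the link from that of the ring substituent; a 4-fluorobenzoyl group on the same nitrogen, or a phenylsulfonyl group, would bear on that question. From the compounds shown here alone, it also remains open how a benzyl group, with a plain methylene link, or a 3,4-dimethoxybenzoyl group would behave at this position.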